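Pyridyl replacement in a trifluoromethyl-pyrazole amide series

The compounds below may be only part of what the source reports. "The series", "measured", "known", "first", "only" and "open" are said of these compounds alone.

Compound 2 `Cc1ccnc(-c2noc([C@H](C)NC(=O)c3cc(C(F)(F)F)nn3C)n2)c1` gives 4470 nM in an assay on T-REx-293 cells for inhibition of potassium channel subfamily T member 1 (Homo sapiens), read by patch clamp (on this read-out higher numbers stand for weaker inhibition and lower numbers for stronger inhibition), the higher of the two numbers at hand; its neighbour compound 1 `Cc1cncc(-c2noc([C@H](C)NC(=O)c3cc(C(F)(F)F)nn3C)n2)c1` gives 1370 nM in this assay, and the step of a 3.3-fold higher number from compound 1 to compound 2 (0.51 log units; beyond the scatter) shows how much one change of the pyridyl pattern moved the number. Compound 3 `C[C@H](NC(=O)c1cc(C(F)(F)F)nn1C)c1nc(-c2ccncc2)no1` differs from compound 2 by pyridin-4-yl in place of 4-methylpyridin-2-yl on an aromatic carbon. Within the data shown here, only that one step bears on this change, and it points neither way for a nitrogen shift with loss of the methyl, so a step of similar size in either direction, or none beyond the scatter, is expected. The estimated step is a 1.7-fold lower number from compound 2 to compound 3 (0.22 log units; within the scatter), and compound 3 is expected to give 2700 nM, within 900 nM to 8000 nM.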

Compound 3, half-maximal inhibitory concentration: 5250 nM
Beside the measured number, compound 3's estimate is 1.9-fold (0.29 log units) below it; measured number inside the range.
By their numbers in this assay, from the lowest: compound 1; then compounds 2 and 3 (each within the scatter of the next).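

Compound 3 shows that replacing 4-methylpyridin-2-yl with pyridin-4-yl, with one heavy atom fewer, leaves the number effectively unmoved, with a 1.2-fold higher number from compound 2 to compound 3 (0.07 log units; within the scatter). Set against the 5-methylpyridin-3-yl group, pyridin-4-yl gives a 3.8-fold higher number from compound 1 to compound 3 (0.58 log units; beyond the scatter), so among these three compounds only compound 1 stands apart, while compound 2 and compound 3 cannot be told apart. Nothing measured here gives a reason for this gap. The compounds shown leave open whether the methyl group or the place of the ring nitrogen matters for compound 1, and how an unsubstituted pyridin-3-yl, a phenyl or a methoxypyridinyl group would read at this position.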